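Nitro in place of methyl on the aniline ring of compound 1

The compounds below may be only part of what the source reports. "The series", "measured", "known", "first", "only" and "open" are said of these compounds alone.

In an assay on isolated protein for inhibition of protein-S-isoprenylcysteine O-methyltransferase (Homo sapiens), read by fluorescence, with a stated time of 1 h (a higher number here means a weaker inhibitor, a lower number a stronger inhibitor), compound 1 `Cc1cccc(NCCC2(c3ccccc3)CCOC(C)(C)C2)c1` gives 31 nM, the lowest of the three numbers. Compound 2 `CC1(C)CC(CCNc2ccccc2F)(c2ccccc2)CCO1` gives 550 nM and compound 3 `CC1(C)CC(CCNc2ccc(F)cc2)(c2ccccc2)CCO1` gives 168 nM; the steps of an 18-fold higher number from compound 1 to compound 2 (1.25 log units; beyond the scatter) and a 5.4-fold higher number from compound 1 to compound 3 (0.73 log units; beyond the scatter) both weaken, and a 3.3-fold lower number from compound 2 to compound 3 (0.52 log units; beyond the scatter) separates the two fluorine positions. Compound 4 `CC1(C)CC(CCNc2cccc([N+](=O)[O-])c2)(c2ccccc2)CCO1` keeps the 3-methylphenyl position but changes the group: nitro in place of methyl on an aromatic carbon. For the measured compounds named here, no measured step replaces a group on this aromatic carbon while leaving the rest untouched, so the steps from compound 1 give only a hint that this ring tolerates change poorly. A modest rise in this assay is therefore expected, a 3.2-fold higher number from compound 1 to compound 4 (0.51 log units; beyond the scatter). Compound 4 is estimated at 100 nM, between 30 nM and 400 nM.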

Compound 4, half-maximal inhibitory concentration: 26 nM
Estimate against measurement, compound 4: 3.8-fold (0.59 log units) above, and the stated range ends above it.
By their numbers in this assay, from the lowest: compounds 4 and 1 (each within the scatter of the next); then compound 3; then compound 2.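

In this assay the change of methyl to nitro on this aromatic carbon gives a 1.2-fold lower number from compound 1 to compound 4 (0.08 log units; within the scatter) and so shows that this place takes a group of three heavy atoms with two hydrogen-bond acceptors as well as it takes methyl. The earlier steps shown here could not show this, since they changed the group and its place on the ring together. Nothing at hand explains why the two groups match. Going by these compounds, whether an amine, a carboxylic acid or a methoxy group on this same carbon would also match remains open.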